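Chloro for Fluoro on the Aryl-Oxadiazole Arm

The source may hold more compounds than are shown below. What is called first, only, known or untested is meant among the compounds shown, and "the series" means these compounds.

Compound 1 `N#Cc1ccc(-c2cnc3[nH]cc(-c4nnc(-c5ccc(F)cc5)o4)c(=O)c3c2)cc1`: 10.2%
Compound 2 `O=c1c(-c2nnc(-c3ccc(F)cc3)o2)c[nH]c2ncc(-c3cccnc3)cc12`: 9.87%
Compound 3 `O=c1c(-c2nnc(-c3ccc(F)cc3)o2)c[nH]c2ncc(-c3ccncc3)cc12`: 7.54%

In a functional assay on HCT-116 cells (Homo sapiens) for inhibition, read by MTT assay, with a stated time of 24 h, tested at 2.5 uM (a higher number here means more inhibition of growth at the concentration tested, a lower number less inhibition of growth), compound 2 stands second highest of the three numbers, though all three sit close together: a number 0.3 percentage points lower from compound 1 to compound 2 (within the scatter), a number 2.3 percentage points lower from compound 2 to compound 3 (within the scatter) and a number 2.7 percentage points lower from compound 1 to compound 3 (within the scatter), so nothing separates them beyond the scatter. Compound 4 `O=c1c(-c2nnc(-c3ccc(Cl)cc3)o2)c[nH]c2ncc(-c3cccnc3)cc12` has not been measured. It differs from compound 2 by chloro in place of fluoro on an aromatic carbon. None of the three measured steps touches this part of the molecule; each of them swaps the aryl group on the other side of the shared core, and each was within the scatter. There is therefore no measured basis for expecting a shift, and compound 4 is expected to give about 10%, within 3% to 18%, a step of a number 0.1 percentage points higher from compound 2 to compound 4 (within the scatter) that is estimated to stay within the scatter.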

Compound 4, percent growth inhibition at one concentration: 10.4%
For compound 4 the middle estimate is 0.4 percentage points below the measured one, within the range that was stated.
By their numbers in this assay, from the lowest: compounds 3, 2, 1 and 4 (each within the scatter of the next).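

The swap from 4-fluorophenyl to 4-chlorophenyl is the first change shown on the aryl-oxadiazole arm rather than on the other side of the shared core, and in this assay it gives a number 0.5 percentage points higher from compound 2 to compound 4 (within the scatter) at this one concentration. This position therefore tolerates one halogen in place of the other without leaving the scatter. Nothing available explains this result.

Still open, on these data alone, is whether an amine or a carboxylic acid in place of the halogen would move the number beyond the scatter. Also open, as far as these compounds go, is whether chloro behaves alike with 4-cyanophenyl or pyridin-4-yl on the other side.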